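This account rests on a few compounds, and the source may have more. Where it says the series, first, only, none or still open, it means among the compounds named here.

The compounds share one core, first seen in compound 1 `COc1cc(C2CC(c3cc4ccccc4o3)=NN2C(=O)Nc2ccccc2)ccc1O`, and differ in the group on the amide-type nitrogen. In a functional assay on microsomes from liver (Rattus norvegicus, strain Wistar) for inhibition, with a stated time of 15 min (a lower number here means a stronger inhibitor, a higher number a weaker inhibitor), compound 1 gives 116000000 nM. Compound 2 `COc1cc(C2CC(c3cc4ccccc4o3)=NN2C(=O)Nc2ccccc2O)ccc1O` carries 2-hydroxyphenyl there, and in this assay compound 2 gives 22000000 nM. Compound 3 `COc1cc(NC(=O)N2N=C(c3cc4ccccc4o3)CC2c2ccc(O)c(OC)c2)ccc1O` carries 4-hydroxy-3-methoxyphenyl, and in this assay compound 3 gives 12000000 nM. Compound 2 thus sits second highest of the three numbers: the step of a 5.3-fold lower number from compound 1 to compound 2 (0.72 log units; beyond the scatter) lies beyond the scatter, whereas the step of a 1.8-fold lower number from compound 2 to compound 3 (0.26 log units; within the scatter) does not.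

Compound 4 `COc1cc(C2CC(c3cc4ccccc4o3)=NN2C(=O)Nc2ccc(O)cc2)ccc1O` is reached from compound 2 by a change in which (4-hydroxyphenyl in place of 2-hydroxyphenyl on an amide-type nitrogen). Among the compounds with values here, three measured steps bear on it. The step of a 5.3-fold lower number from compound 1 to compound 2 (0.72 log units; beyond the scatter) shows that a hydroxy on this ring counts against plain phenyl, and the step of a 9.7-fold lower number from compound 1 to compound 3 (0.99 log units; beyond the scatter) shows the same for a ring bearing 4-hydroxy alongside methoxy. Yet the step of a 1.8-fold lower number from compound 2 to compound 3 (0.26 log units; within the scatter), which compares the two hydroxy-bearing rings, stays within the scatter. The author therefore expects no step beyond the scatter in this assay, with at most a slight drift toward a lower number, close to compound 3. Compound 4 is expected to give 15000000 nM, within a range from 6000000 nM to 40000000 nM. The expected step is a 1.5-fold lower number from compound 2 to compound 4 (0.17 log units; within the scatter).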

Compound 4, half-maximal inhibitory concentration: 15000000 nM
Estimate against measurement, compound 4: no gap at the digits printed, and the stated range covers the measured number.
By their numbers in this assay, from the lowest: compounds 3, 4 and 2 (each within the scatter of the next); then compound 1.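

In this assay, the exchange of 2-hydroxyphenyl for 4-hydroxyphenyl on the amide-type nitrogen tests the place of the hydroxy directly, with the same atoms joined differently, and it gives a 1.5-fold lower number from compound 2 to compound 4 (0.17 log units; within the scatter), so these two placements cannot be told apart here. The methoxy can now be assessed on its own as well: hydrogen in place of methoxy on an aromatic carbon gives a 1.3-fold higher number from compound 3 to compound 4 (0.10 log units; within the scatter), so the methoxy of compound 3 makes no readable difference on a ring that carries the 4-hydroxy. Hydroxy in place of hydrogen on the plain phenyl gives a 7.7-fold lower number from compound 1 to compound 4 (0.89 log units; beyond the scatter), which adds a second hydroxy placement to the one seen with compound 2 and leaves compound 1 apart from compounds 2, 3 and 4, with none of those three going against this.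

Going by these compounds, it remains open whether an aminophenyl or a carboxyphenyl on the amide-type nitrogen, or a longer chain such as benzyl in place of the ring, would give numbers like those of compounds 2, 3 and 4. Nothing in hand speaks to the reason for any of these steps.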